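Lengthening a Hydroxy Side Chain on Compound 1

The source may report more compounds than this note shows. Statements on the series, on what has been measured and on what is new or still open speak of the compounds shown alone.

Compound 1, `O=S1(=O)Cc2nc(-c3cc(F)c(Cl)cc3F)nc(N3CCC(CO)CC3)c2C1`: 3.9 nM
Compound 2, `NC(=O)C1CCN(c2nc(-c3cc(F)c(Cl)cc3F)nc3c2CS(=O)(=O)C3)CC1`: 21 nM

In a functional assay on HEK293 cells for agonist activity at Glucose-dependent insulinotropic receptor (Homo sapiens), read by reporter gene assay and cAMP accumulation, with a stated time of 6 h (a higher number here means that more compound is needed for the effect, a lower number that less compound is needed), compound 1 gives 3.9 nM, the lowest of the two numbers shown. Compound 2 gives 21 nM, and the step of a 5.4-fold higher number from compound 1 to compound 2 (0.73 log units; beyond the scatter) counts as modest. Compound 3, `O=S1(=O)Cc2nc(-c3cc(F)c(Cl)cc3F)nc(N3CCC(CCO)CC3)c2C1`, differs from compound 1 by hydroxymethyl in place of hydroxy on a saturated chain carbon bound to a saturated ring carbon. Among the measured compounds shown here, no measured step lengthens this chain; the only one, a 5.4-fold higher number from compound 1 to compound 2 (0.73 log units; beyond the scatter), exchanges the group rather than extending it, so it bears only loosely. For compound 3 a small step is expected, a 1.5-fold higher number from compound 1 to compound 3 (0.19 log units; within the scatter), probably toward a higher number. Compound 3 is therefore estimated at 6 nM, within a range from 2 nM to 20 nM.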

Compound 3, effective concentration (reported as EC, without a stated level of effect): 2.8 nM
Compound 3: the middle estimate sits 2.1-fold (0.33 log units) above what was measured; the measured number falls inside the stated range.
By their numbers in this assay, from the lowest: compounds 3 and 1 (each within the scatter of the next); then compound 2.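

In this assay the longer chain gives a 1.4-fold lower number from compound 1 to compound 3 (0.14 log units; within the scatter) and so, on this saturated ring carbon, 2-hydroxyethyl serves as well as hydroxymethyl. Set against carbamoyl, the same chain gives a 7.5-fold lower number from compound 2 to compound 3 (0.88 log units; beyond the scatter) and thus both hydroxy chains now stand apart from the carbamoyl compound. Nothing measured here explains these differences.

Still open, from the compounds shown here alone, is whether a 3-hydroxypropyl chain would hold this level. Also open, going by these compounds, is whether the hydroxy group matters at all, which a plain ethyl group or a 2-aminoethyl chain on the same carbon could test.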